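This account rests on a few compounds, and the source may have more. Where it says the series, first, only, none or still open, it means among the compounds named here.

Measured in an assay on CHO cells for displacement of a labelled ligand from adenosine receptor A3 (Homo sapiens), read by scintillation counting, with a stated time of 60 min; a higher number here means a weaker inhibitor, a lower number a stronger inhibitor:
compound 1 `CNC(=O)[C@@]12C[C@@H]1[C@@H](n1cnc3c(NC)nc(C#Cc4ccc(OC)cc4)nc31)[C@H](O)[C@@H]2O`, 0.63 nM
compound 2 `CNC(=O)[C@@]12C[C@@H]1[C@@H](n1cnc3c(NC)nc(C#Cc4ccc(CO)cc4)nc31)[C@H](O)[C@@H]2O`, 2.16 nM
compound 3 `CNC(=O)[C@@]12C[C@@H]1[C@@H](n1cnc3c(NC)nc(C#Cc4cccnn4)nc31)[C@H](O)[C@@H]2O`, 3.53 nM

Among these three, compound 1 has the lowest number, and therefore the strongest binding, in this assay. Its nearest neighbour is compound 2, reached by a 3.4-fold higher number from compound 1 to compound 2 (0.54 log units; beyond the scatter), and compound 3 lies furthest away, reached by a 5.6-fold higher number from compound 1 to compound 3 (0.75 log units; beyond the scatter). Compound 4 `CNC(=O)[C@@]12C[C@@H]1[C@@H](n1cnc3c(NC)nc(C#Cc4cc(C)c(C)o4)nc31)[C@H](O)[C@@H]2O` has not yet been measured. It differs from compound 1 in one place: 4,5-dimethylfuran-2-yl in place of 4-methoxyphenyl on a triple-bonded carbon. Going by the values given here, of the measured steps, the one from compound 1 to compound 3 bears most directly on this change, since it likewise replaces the 4-methoxyphenyl on the triple-bonded carbon with a smaller aromatic ring carrying a hetero atom, and it gave a 5.6-fold higher number from compound 1 to compound 3 (0.75 log units; beyond the scatter). The step of a 3.4-fold higher number from compound 1 to compound 2 (0.54 log units; beyond the scatter), a change on the same ring, points in the same direction. Both measured changes raised the number, so a higher number, meaning weaker binding, is expected for compound 4 as well, and of modest size. Compound 4 is therefore estimated at 2 nM, within a range from 0.6 nM to 7 nM. This corresponds to an expected 3.2-fold higher number from compound 1 to compound 4 (0.50 log units; beyond the scatter).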

Compound 4, inhibition constant: 1.45 nM
For compound 4 the middle estimate is 1.4-fold (0.14 log units) above the measured one; the range from low to high includes it.
By their numbers in this assay, from the lowest: compound 1; then compounds 4, 2 and 3 (each within the scatter of the next, the first and the last beyond it).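

In this assay, going by these compounds alone, unlike the earlier compounds, compound 4 places a five-membered aromatic ring with 1 hetero atom on the triple-bonded carbon, and replacing 4-methoxyphenyl with 4,5-dimethylfuran-2-yl gives a 2.3-fold higher number from compound 1 to compound 4 (0.36 log units; beyond the scatter) and leaves compound 1 with the lowest number of the four. Replacing pyridazin-3-yl with the same group gives a 2.4-fold lower number from compound 3 to compound 4 (0.39 log units; beyond the scatter) and so shows that the choice of ring at this position can move the number in either direction, depending on the starting group. Replacing 4-(hydroxymethyl)phenyl gives a 1.5-fold lower number from compound 2 to compound 4 (0.17 log units; within the scatter) and so these two compounds cannot be told apart, while nothing available here explains any of these differences.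

As far as these compounds go, what the two methyl groups add on their own remains open, as does whether furan-2-yl without them would come closer to compound 1. Also open, from the compounds shown here alone, is how an amine or a carboxylic acid on the ring, or a longer chain in place of either methyl group, would shift the number.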